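Amine tail variation in the diaryl ether urea series

The compounds below may be only part of what the source reports. "The series", "measured", "known", "first", "only" and "open" are said of these compounds alone.

Compound 1 `COc1cc2c(Oc3c(F)cc(NC(=O)NN4C(=O)CSC4c4c(F)cccc4F)cc3F)ccnc2cc1OCCCN1CCc2sccc2C1` and compound 2 `COc1cc2c(Oc3c(F)cc(NC(=O)NN4C(=O)CSC4c4c(F)cccc4F)cc3F)ccnc2cc1OCCCN1C[C@H]2CCCC[C@H]2C1` share the whole core and differ only in the cyclic amine sitting on the saturated chain carbon, three bonds along the chain from an oxygen on an aromatic ring. In a functional assay on HT-29 cells (Homo sapiens) for antiproliferative activity, read by MTT assay, with a stated time of 72 h (a higher number here means a weaker inhibitor, a lower number a stronger inhibitor), compound 1 gives 1410 nM. In this assay, for the measured compounds named here, compound 2 gives 470 nM, the lowest of the two numbers; the one measured step, a 3.0-fold lower number from compound 1 to compound 2 (0.48 log units; beyond the scatter), separates them beyond the scatter. Compound 3 `COc1cc2c(Oc3c(F)cc(NC(=O)NN4C(=O)CSC4c4c(F)cccc4F)cc3F)ccnc2cc1OCCCN1CCC(N2CCCCC2)CC1` alters the same place again: a group of 12 heavy atoms (10 carbon, 2 nitrogen; 2 six-membered non-aromatic rings with 1 hetero atom each) in place of a group of 9 heavy atoms (8 carbon, 1 nitrogen; one five-membered non-aromatic ring with 1 hetero atom, one six-membered non-aromatic ring of carbon only), on a saturated chain carbon, three bonds along the chain from an oxygen on an aromatic ring. Going by the values given here, the single measured step touches this position, but it swapped one fused bicyclic amine for another rather than bringing in a second six-membered ring, so it guides the direction only loosely. Among the compounds with values here, with no closer precedent, no step beyond the scatter is expected in this assay, though a change at this place has already moved the number by a 3.0-fold lower number from compound 1 to compound 2 (0.48 log units; beyond the scatter), so a shift of similar size in either direction remains possible. For compound 3 the estimated step is a 1.4-fold higher number from compound 2 to compound 3 (0.14 log units; within the scatter). Compound 3 is therefore expected to give about 650 nM in this assay, within a range from 250 nM to 1700 nM.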

Compound 3, half-maximal inhibitory concentration: 280 nM
Compound 3: middle estimate off by 2.3-fold (0.37 log units), on the high side, and the stated range covers the measured number.
By their numbers in this assay, from the lowest: compounds 3 and 2 (each within the scatter of the next); then compound 1.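

Notes on the chain-end amine: in this assay, a 1.7-fold lower number from compound 2 to compound 3 (0.22 log units; within the scatter) shows that at this saturated chain carbon, three bonds along the chain from an oxygen on an aromatic ring, the 4-(piperidin-1-yl)piperidin-1-yl group and the fused amine of compound 2 cannot be told apart. The larger group, with its two non-aromatic six-membered rings, therefore brings no readable step relative to compound 2. Against the amine of compound 1, with its five-membered aromatic ring, the same group gives a 5.0-fold lower number from compound 1 to compound 3 (0.70 log units; beyond the scatter), so compound 1 now stands apart from both other compounds, and only the exchange of that amine has produced a step beyond the scatter. No measurement at hand bears on the reason for these numbers.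

Still open, on these data alone, is whether a morpholine or an open-chain diethylamino group at this place would stay with compound 2 and compound 3 or move towards compound 1. The compounds shown also leave open how these amines behave on a longer chain, and whether the mirror-image form of the fused amine in compound 2 would give a comparable number.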